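Fluorine Position on the Sulfonyl Ring in Two Cores

The source may report more compounds than this note shows. Statements on the series, on what has been measured and on what is new or still open speak of the compounds shown alone.

Compound 1, `O=C(CN1CCN(S(=O)(=O)c2ccc(F)cc2)CC1)Nc1ccc(F)cc1`: 11600 nM
Compound 2, `O=C(CN1CCN(S(=O)(=O)c2ccccc2F)CC1)Nc1ccc(F)cc1`: 13600 nM
Compound 3, `O=C(CN1CCN(S(=O)(=O)c2ccc(F)cc2)CC1)Oc1ccccc1-c1ccccc1`: 23800 nM

In an in vitro assay on HEK ts201 cells for negative allosteric modulation of Neuronal acetylcholine receptor; alpha3/beta4 (Homo sapiens), read by fluorescence and calcium flux, with a stated time of 1.5 s (a lower number here means a stronger inhibitor, a higher number a weaker inhibitor), compound 1 gives 11600 nM and compound 2 gives 13600 nM; these two differ by 2-fluorophenyl in place of 4-fluorophenyl on a sulfonyl sulfur, a step of a 1.2-fold higher number from compound 1 to compound 2 (0.07 log units; within the scatter). Compound 3, which carries a different core, gives 23800 nM in this assay; the difference between its core and that of compound 1 is not broken down here, and its value sits within the scatter of compound 2 but beyond the scatter of compound 1.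

Compound 4, `O=C(CN1CCN(S(=O)(=O)c2ccccc2F)CC1)Oc1ccccc1-c1ccccc1`, has not yet been measured. It relates to compound 3 as compound 2 relates to compound 1: the change is 2-fluorophenyl in place of 4-fluorophenyl on a sulfonyl sulfur, the same change at the same place. Since that change gave only a 1.2-fold higher number from compound 1 to compound 2 (0.07 log units; within the scatter) on the first core, compound 3 to compound 4 is expected to move by about a 1.2-fold higher number from compound 3 to compound 4 (0.07 log units; within the scatter) in this assay, a step resting on a single prior example and therefore uncertain. Compound 4 is thus estimated at 28000 nM, with a plausible range from 12000 nM to 65000 nM.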

Compound 4, half-maximal inhibitory concentration: 23500 nM
For compound 4 the middle estimate is 1.2-fold (0.08 log units) above the measured one, and the stated range covers the measured number.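

In this assay, among the compounds shown here, 2-fluorophenyl in place of 4-fluorophenyl on the sulfonyl sulfur gives a 1.0-fold lower number from compound 3 to compound 4 (0.01 log units; within the scatter), so on the core of compound 3, as on the core of compound 1, this change produces no step that can be told from the scatter. The change therefore behaves alike on the two cores: the same change on two cores in this assay, a 1.2-fold higher number (0.07 log units; within the scatter) from compound 1 to compound 2 and a 1.0-fold lower number (0.01 log units; within the scatter) from compound 3 to compound 4, 1.2-fold (0.07 log units) apart, within the scatter of two such steps This agreement concerns a change that is small on both cores, so it does not show that a larger step would carry over in the same way, and two cores say nothing about any further core in this series.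

The compounds shown leave open whether a different group on the sulfonyl sulfur, such as a methyl, a pyridine or a methoxyphenyl, would move the number on either core. On these data alone, it also remains open what an amine or a carboxylic acid on the sulfonyl ring would do, and whether such a step would match on the two cores.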